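The source may hold more compounds than are shown below. What is called first, only, known or untested is meant among the compounds shown, and "the series" means these compounds.

Of the compounds shown here, three built on one shared core have been measured in an assay for inhibition of Indoleamine 2,3-dioxygenase 1 (Homo sapiens), read by fluorescence, with a stated time of 1 h; on this read-out higher numbers stand for weaker inhibition and lower numbers for stronger inhibition. Compound 1 `NS(=O)(=O)CC(=O)NCCSc1nonc1/C(=N/O)Nc1cccc(Cl)c1` gives 21 nM. Compound 2 `NS(=O)(=O)CC(=O)NCCSc1nonc1/C(=N/O)Nc1cccc(Br)c1` gives 30 nM. Compound 3 `N#Cc1cc(N/C(=N\O)c2nonc2SCCNC(=O)CS(N)(=O)=O)ccc1F` gives 150 nM, the highest of the three numbers, so it is the weakest inhibitor of the set. The step of a 1.4-fold higher number from compound 1 to compound 2 (0.15 log units; within the scatter) shows that exchanging one halogen for another barely moves the number. The steps of a 7.1-fold higher number from compound 1 to compound 3 (0.85 log units; beyond the scatter) and a 5.0-fold higher number from compound 2 to compound 3 (0.70 log units; beyond the scatter) show that the 3-cyano-4-fluorophenyl group gives a clearly weaker result than either halogen-bearing group.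

Compound 4 `NS(=O)(=O)CC(=O)NCCSc1nonc1/C(=N/O)Nc1ccc(F)c(Br)c1` has not yet been measured. It differs from compound 3 by bromo in place of cyano on an aromatic carbon. Compound 4 thus carries the bromo group found in compound 2 together with the fluoro group found in compound 3. The step that bears most directly on it is a 5.0-fold higher number from compound 2 to compound 3 (0.70 log units; beyond the scatter), since compound 2 holds bromo without fluoro and gives 30 nM. Among the measured compounds shown here, no measured pair shows what the fluoro group alone does. The number for compound 4 in this assay is therefore expected to drop, with a 3.8-fold lower number from compound 3 to compound 4 (0.57 log units; beyond the scatter), reversing most of the earlier loss. Compound 4 is estimated at 40 nM, within a range of 15 nM to 110 nM.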

Compound 4, half-maximal inhibitory concentration: 71 nM
For compound 4 the middle estimate is 1.8-fold (0.25 log units) below the measured one, within the range that was stated.
By their numbers in this assay, from the lowest: compounds 1 and 2 (each within the scatter of the next); then compound 4; then compound 3.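

In this assay, a 2.1-fold lower number from compound 3 to compound 4 (0.32 log units; beyond the scatter) shows that with the fluoro group held constant, bromo in place of cyano lowers the number, which means the cyano group accounts for only part of the loss seen for compound 3. Among the compounds shown here, the fluoro group can now also be read on its own for the first time: adding it to the bromo compound gives a 2.4-fold higher number from compound 2 to compound 4 (0.37 log units; beyond the scatter), a real cost rather than a neutral addition, and the 3-bromo-4-fluorophenyl group also falls short of the 3-chlorophenyl group, with a 3.4-fold higher number from compound 1 to compound 4 (0.53 log units; beyond the scatter). So the gap between compound 2 and compound 3 comes from two separate changes, the added fluoro group and the exchange of bromo for cyano, but nothing measured here explains why either change moves the number as it does.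

As far as these compounds go, it remains open whether adding a fluoro group to compound 1 would cost as much as it does on compound 2. Also open, from the compounds shown here alone, is how a methyl or methoxy group would compare with bromo and cyano on the same aromatic carbon, with the fluoro group kept in place.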